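The source may report more compounds than this note shows. Statements on the series, on what has been measured and on what is new or still open speak of the compounds shown alone.

Working notes on the series. Compound 2 `COc1ccc2nc(-c3ccc(-n4c(C)ccc4-c4ccc(F)cc4)cc3)sc2c1` in an ADME assay on MCF-10A cells (Homo sapiens) for cytotoxicity, read by MTT assay, with a stated time of 72 h (a higher number here means a weaker inhibitor, a lower number a stronger inhibitor), gives 38300 nM. Compound 1 `COc1ccc2nc(-c3ccc(-n4c(C)ccc4-c4ccc(C)cc4)cc3)sc2c1` in this assay gives 34000 nM. Of the two numbers in hand, compound 2 holds the highest, and the nearest to it is compound 1, a gap that lies within the usual scatter, so no order between the two can be read. Among the measured compounds shown here, the single measured step, a 1.1-fold higher number from compound 1 to compound 2 (0.05 log units; within the scatter), exchanged one substituent on the aromatic carbon para to a large group for another and left the number within the scatter.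

Compound 3 `COc1ccc2nc(-c3ccc(-n4c(C)ccc4-c4ccc([N+](=O)[O-])cc4)cc3)sc2c1` differs from compound 2 by nitro in place of fluoro on an aromatic carbon; cut one bond further out, the change reads 4-fluorophenyl to 4-nitrophenyl. For the measured compounds named here, the only step that bears on it is a 1.1-fold higher number from compound 1 to compound 2 (0.05 log units; within the scatter), a swap at the same aromatic carbon that produced nothing beyond the scatter. Going by the values given here, no nitro-bearing analogue has been measured, so the guide is thin. On this basis the step of a 1.0-fold lower number from compound 2 to compound 3 (0.00 log units; within the scatter) is expected to remain within the scatter in this assay, with no direction favoured. Compound 3 is accordingly estimated at 38000 nM in this assay, with a range from 15000 nM to 95000 nM.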

Compound 3, half-maximal inhibitory concentration: 34900 nM
For compound 3 the middle estimate is 1.1-fold (0.04 log units) above the measured one; low and high end bracket the measured number.
By their numbers in this assay, from the lowest: compounds 1, 3 and 2 (each within the scatter of the next).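

In this assay the aromatic carbon para to a large group has now carried methyl, fluoro and nitro, and exchanging fluoro for nitro gives a 1.1-fold lower number from compound 2 to compound 3 (0.04 log units; within the scatter) while exchanging methyl for nitro gives a 1.0-fold higher number from compound 1 to compound 3 (0.01 log units; within the scatter) and so no order can be read among the three compounds. Nitro enters with 3 heavy atoms and 2 hydrogen-bond acceptors where fluoro has 1 heavy atom and 0 hydrogen-bond acceptors, so at this position even an exchange differing in these counts stays within the scatter for the compounds in hand. No supporting measurement is available that could account for this result.

From the compounds shown here alone, whether an amine, a carboxylic acid or a longer chain at this aromatic carbon would carry the number beyond the scatter stays open. Also open, going by these compounds, is whether any other place on the shared core moves the number in this assay at all, since compound 1, compound 2 and compound 3 differ only at this one carbon.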